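Compound 1 Gains a 2,6-Difluorophenyl Group

The source may hold more compounds than are shown below. What is called first, only, known or untested is meant among the compounds shown, and "the series" means these compounds.

So far, three compounds have numbers in a functional assay on HeLa cells (Homo sapiens) for inhibition, read by CCK-8 assay, with a stated time of 72 h; a lower number here means a stronger inhibitor, a higher number a weaker inhibitor. There, compound 1 `Nc1ccccc1NC(=O)c1ccc(CNC(=O)c2n[nH]cc2NC(=O)c2ccccc2)cc1` gives 4060 nM, the lowest of the three numbers. Compound 2 `O=C(NO)c1ccc(CNC(=O)c2n[nH]cc2NC(=O)c2ccccc2F)cc1` gives 6610 nM, which lies within the scatter of the value for compound 1. Going by the values given here, compound 3 `O=C(NO)c1ccc(CNC(=O)c2n[nH]cc2NC(=O)c2ccccc2Cl)cc1` gives 16200 nM, and the gap between this number and the one for compound 1 lies beyond the scatter.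

Compound 4 `Nc1ccccc1NC(=O)c1ccc(CNC(=O)c2n[nH]cc2NC(=O)c2c(F)cccc2F)cc1` keeps the core of compound 1 and changes one group: 2,6-difluorophenyl in place of phenyl on a carbonyl carbon. In other words, 2,6-difluorophenyl stands in place of phenyl on a carbonyl carbon.

Among the compounds with values here, the only measured step involving a halogen on an aromatic ring is a 2.5-fold higher number from compound 2 to compound 3 (0.39 log units; beyond the scatter), with chloro in place of fluoro on an aromatic carbon. That step is modest, and it is only an indirect guide. Within the data shown here, no measured pair shows a plain phenyl gaining fluoro groups, and no measured compound carries two of them.

With so little to go on, only a small move towards a higher number is expected in this assay, and it may well stay within the scatter. The expected change is a 1.2-fold higher number from compound 1 to compound 4 (0.09 log units; within the scatter). Compound 4 is estimated at 5000 nM, with an expected range from 2000 nM to 13000 nM.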

Compound 4, half-maximal inhibitory concentration: 4480 nM
Compound 4: the middle estimate sits 1.1-fold (0.05 log units) above what was measured, and the stated range covers the measured number.
By their numbers in this assay, from the lowest: compounds 1, 4 and 2 (each within the scatter of the next); then compound 3.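

In this assay, going by these compounds alone, the pair of compound 1 and compound 4 gives the only direct reading so far at this position, the aromatic ring on the carbonyl carbon whose other neighbour is an amide-type nitrogen (a 1.1-fold higher number from compound 1 to compound 4 (0.04 log units; within the scatter)). Within the data shown here, on the core of compound 1, 2,6-difluorophenyl and phenyl therefore cannot be told apart in this cell assay, so this one change in the ring leaves the number within the usual scatter, something no earlier pair could show. No measurement offered here gives a reason for this result.

From the compounds shown here alone, it remains open whether other groups on this phenyl ring, such as a single chloro, a methoxy group, an amine or a carboxylic acid, would leave the number just as undisturbed on the core of compound 1. It is also open how 2,6-difluorophenyl would read on the core of compound 2, where the one halogen swap shown does move the number (a 2.5-fold higher number from compound 2 to compound 3 (0.39 log units; beyond the scatter)).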